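Pyrazole for Tetrazole on a Thioether-Linked Side Chain

This account rests on a few compounds, and the source may have more. Where it says the series, first, only, none or still open, it means among the compounds named here.

The account concerns two measured compounds sharing one core and one more compound that is not yet measured. Compound 1 `N#Cc1c(N)nc(SCc2nnn[nH]2)c(C#N)c1-c1ccc(OCC2CC2)cc1` carries a ((1H-tetrazol-5-yl)methyl)sulfanyl arm; in an assay on CHO cells for displacement of a labelled ligand from adenosine receptor A3 (Homo sapiens), read by scintillation counting, with a stated time of 120 min, tested at 1 uM (on this read-out lower numbers stand for less inhibition and higher numbers for more inhibition at the one concentration tested (going by the name of the read-out)), compound 1 gives 1%, the lower of the two numbers available. Among the compounds with values here, compound 2 `C=C(C)COc1ccc(-c2c(C#N)c(N)nc(SCC(N)=O)c2C#N)cc1` differs from it in more than one place, so no single step between them is counted; in this assay compound 2 gives 4%, a number that lies within the usual scatter of the value for compound 1, so the two cannot be told apart.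

Compound 3 `N#Cc1c(N)nc(SCc2ccn[nH]2)c(C#N)c1-c1ccc(OCC2CC2)cc1` is the untested member. It differs from compound 1 in one place: 1H-pyrazol-5-yl in place of 1H-tetrazol-5-yl on a saturated chain carbon bound to a sulfur. Within the data shown here, no measured pair in this set isolates such a change, so there is nothing in the data to anchor its direction. Both measured compounds sit at the low end of the read-out, and compound 3 is expected to remain there, with a step of a number 4 percentage points higher from compound 1 to compound 3 (within the scatter) from compound 1 to compound 3 that is not expected to exceed the scatter. Compound 3 is accordingly estimated at 5%, within -8% to 25%.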

Compound 3, a percentage reported as inhibition, at one concentration (the size of the read-out at that concentration, not a potency): 6%
Beside the measured number, compound 3's estimate is 1 percentage points below it; the range from low to high includes it.
By their numbers in this assay, from the lowest: compounds 1, 2 and 3 (each within the scatter of the next).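

Within the data shown here, the exchange of 1H-tetrazol-5-yl for 1H-pyrazol-5-yl on a saturated chain carbon bound to a sulfur gives the only single-place comparison in this set: in this assay the step is a number 5 percentage points higher from compound 1 to compound 3 (within the scatter). With the rest of compound 1 held constant, the two five-membered aromatic rings therefore cannot be told apart at this position, even though they differ in their count of hetero atoms and of hydrogen-bond acceptors. No measurement shown here offers an explanation for this result.

All three compounds give low numbers at the one concentration tested, so the compounds shown leave open whether any arm on this sulfur can raise the read-out, and compound 2 differs from compound 1 in too many places to add to this comparison. Whether a carboxylic acid, an amine or a longer chain carrying the 1H-pyrazol-5-yl group in place of the (1H-pyrazol-5-yl)methyl arm would give a clearly different number remains an open question.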